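Carbonyl Aryl Swaps Near a Cytotoxicity Limit

This account rests on a few compounds, and the source may have more. Where it says the series, first, only, none or still open, it means among the compounds named here.

Compound 1, `COc1cc(-c2nnc3n2NC(c2ccco2)C(C(=O)c2ccccc2F)S3)cc(OC)c1OC`, gives 78700 nM in a functional assay on A549 cells (Homo sapiens) for cytotoxicity, read by MTT assay, with a stated time of 48 h; a lower number here means a stronger inhibitor, a higher number a weaker inhibitor.
Compound 2, `COc1cc(-c2nnc3n2NC(c2ccco2)C(C(=O)c2cccc4ccccc24)S3)cc(OC)c1OC`, gives > 100000 nM in this assay, which is a limit of the assay and not a number.
Compound 3, `COc1ccc(C(=O)C2Sc3nnc(-c4cc(OC)c(OC)c(OC)c4)n3NC2c2ccco2)cc1`, gives > 100000 nM in this assay, likewise a limit of the assay.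

Compound 3 therefore stands only at a limit, and the set as a whole sits high: the limit of > 100000 nM in this assay, at which 2 of the 3 values shown sit. The change to compound 4, `COc1cc(-c2nnc3n2NC(c2ccco2)C(C(=O)c2cccc(Br)c2)S3)cc(OC)c1OC`, is 3-bromophenyl in place of 4-methoxyphenyl on a carbonyl carbon. The measured steps that touch the same ring on the carbonyl carbon are an at least 1.2-fold higher number from compound 1 to compound 2 (0.10 log units; that floor lies within the scatter) and an at least 1.2-fold higher number from compound 1 to compound 3 (0.10 log units; that floor lies within the scatter), both floors that lie within the scatter, and a step that the two limits leave unreadable from compound 2 to compound 3, which the two limits leave unreadable. None of these steps separates one carbonyl-bound ring from another beyond the scatter, so compound 4 is expected to sit close to its three relatives, with a step of an at least 1.1-fold lower number from compound 3 to compound 4 (0.04 log units; that floor lies within the scatter) that is estimated to be none beyond the scatter. Compound 4 is accordingly estimated at 90000 nM, between 40000 nM and 200000 nM, with a fair chance that this assay again reports only a limit.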

Compound 4, half-maximal inhibitory concentration: 36900 nM
Compound 4: the middle estimate sits 2.4-fold (0.39 log units) above what was measured; the whole stated range lies above it.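

For the compounds shown here, the carbonyl-bound ring does move the reading in this assay: 3-bromophenyl gives the first fully measured step beyond the scatter, a 2.1-fold lower number from compound 1 to compound 4 (0.33 log units; beyond the scatter). Against the two compounds held at a limit, the change gives an at least 2.7-fold lower number from compound 3 to compound 4 (0.43 log units; beyond the scatter) and an at least 2.7-fold lower number from compound 2 to compound 4 (0.43 log units; beyond the scatter), and both of these are floors, so the real steps may be larger. That makes compound 4 the strongest of the four, although the gain over the other three remains modest or is known only as a floor.

Going by these compounds, the step between compound 2 and compound 3 cannot be read, since each of these two compounds stands only at a limit: the limit of > 100000 nM in this assay, at which 2 of the 4 values shown sit. Whether the bromine itself carries the step, and whether a ring bearing chlorine or an amine in its place would read the same, stays open.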